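The source may report more compounds than this note shows. Statements on the series, on what has been measured and on what is new or still open speak of the compounds shown alone.

Measured so far in a functional assay on SK-MES-1 cells (Homo sapiens) for antiproliferative activity; on this read-out lower numbers stand for stronger inhibition and higher numbers for weaker inhibition:
Compound 1 `CC(=O)OC[C@@H]1C=C[C@H](n2cc(F)c(N)nc2=O)O1`: > 100000 nM (a limit)
Compound 2 `CCCC(=O)OC[C@@H]1C=C[C@H](n2cc(F)c(N)nc2=O)O1`: > 100000 nM (a limit)

Compound 2 has no numerical reading in this assay. Compound 2 stands at > 100000 nM, and this value is a limit of the assay. Compound 1 gives > 100000 nM, which is also a limit. Both compounds therefore sit together: the limit of > 100000 nM in this assay, at which 2 of the 2 values shown sit.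

Compound 3 `CCCCC(=O)OC[C@@H]1C=C[C@H](n2cc(F)c(N)nc2=O)O1` differs from compound 2 by one change: methyl in place of hydrogen on a saturated chain carbon, three bonds along the chain from a carbonyl carbon. Cut one bond further out, the same difference reads propyl to butyl.

Within the data shown here, the only measured step bearing on this change is a step that the two limits leave unreadable from compound 1 to compound 2, and it offers no size to carry forward. Compound 3 is therefore expected to lie close to compound 2 in this assay, with no step beyond the scatter and no direction foreseen. The expected change is a number no higher from compound 2 to compound 3 (the limit leaves the size open). For compound 3 the estimated value is 100000 nM, with an expected range from 30000 nM to 300000 nM.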

Compound 3, half-maximal inhibitory concentration: > 100000 nM
Compound 3: a limit, no number; the forecaster's own chance of this, stated with the estimate: 75%; the middle value lies on the limit itself.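

Compound 3 gives > 100000 nM in this assay, which is a limit of the assay. No step can be read among compound 1, compound 2 and compound 3, since all three rest at the same limit: the limit of > 100000 nM in this assay, at which 3 of the 3 values shown sit.

The compounds shown leave open how strongly any of the three inhibits, and whether lengthening the chain changes the read-out at all.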